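Ring-opened analogue of compound 3: expected potency loss

The source may hold more compounds than are shown below. What is called first, only, known or untested is meant among the compounds shown, and "the series" means these compounds.

Measured compounds and their values in a functional assay on MCF7 cells (Homo sapiens) for antiproliferative activity; a lower number here means a stronger inhibitor of growth, a higher number a weaker inhibitor of growth:
compound 1, `CC/C=C\[C@H](C)[C@H](OC(N)=O)[C@@H](C)[C@H](O)[C@@H](C)C/C(C)=C\[C@H](C)[C@@H](O)[C@@H](C)/C=C\[C@@H](O)C[C@@H]1OC(=O)[C@H](C)[C@@H](O)[C@H]1C`: 6.2 nM
compound 2, `CC/C=C\[C@H](C)[C@H](OC(N)=O)[C@@H](C)[C@H](O)[C@@H](C)C/C(C)=C\[C@H](C)[C@@H](O)[C@@H](C)/C=C\[C@@H](O)C[C@H](O)[C@H](C)C[C@H](C)C(=O)OC`: 1000 nM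
compound 3, `CC/C=C\[C@H](C)[C@H](OC(N)=O)[C@@H](C)[C@H](O)[C@@H](C)C/C(C)=C\[C@H](C)[C@@H](O)[C@@H](C)/C=C\[C@@H](O)C[C@H]1CCC(=O)O1`: 6.4 nM

Compound 3 stands second highest of the three numbers; its nearest neighbour is compound 1 (a 1.0-fold higher number from compound 1 to compound 3 (0.01 log units; within the scatter)), the two being indistinguishable within the scatter, while compound 2 lies furthest away (a 160-fold lower number from compound 2 to compound 3 (2.19 log units; beyond the scatter)).

Compound 4, `CC/C=C\[C@H](C)[C@H](OC(N)=O)[C@@H](C)[C@H](O)[C@@H](C)C/C(C)=C\[C@H](C)[C@@H](O)[C@@H](C)/C=C\[C@@H](O)C[C@H](O)[C@H](C)CO`, has not yet been measured. It differs from compound 3 in one place: a group of 6 heavy atoms (4 carbon, 2 oxygen; no ring) in place of a group of 6 heavy atoms (4 carbon, 2 oxygen; one five-membered non-aromatic ring with 1 hetero atom), on a saturated chain carbon, two bonds along the chain from a double-bonded chain carbon and an oxygen on a saturated carbon.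

For the measured compounds named here, two measured steps bear directly on this kind of change. Going from the six-membered ring of compound 1 to the open chain of compound 2 gave a 160-fold higher number from compound 1 to compound 2 (2.21 log units; beyond the scatter), and closing that chain into the five-membered ring of compound 3 gave a 160-fold lower number from compound 2 to compound 3 (2.19 log units; beyond the scatter) back. Both show that the open-chain group in this position is tied to a large rise in the number, beyond the scatter. Going by the values given here, compound 4 carries an open chain of the same heavy-atom count as the ring of compound 3, so a large step in the same direction is expected, though the chain in compound 4 is not the same as the one in compound 2 and the size is less certain.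

Compound 4 is therefore estimated to give 500 nM in this assay, within a range of 100 nM to 3000 nM, an expected step of a 78-fold higher number from compound 3 to compound 4 (1.89 log units; beyond the scatter).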

Compound 4, concentration for 50% growth inhibition: 1000 nM
For compound 4 the middle estimate is 2.0-fold (0.30 log units) below the measured one; the range from low to high includes it.
By their numbers in this assay, from the lowest: compounds 1 and 3 (each within the scatter of the next); then compounds 2 and 4 (each within the scatter of the next).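

In this assay, the open chain of compound 2 is not a special case tied to its far end: hydroxy in place of 1-(methoxycarbonyl)ethyl, on a saturated chain carbon, three bonds along the chain from an oxygen on a saturated carbon, leaves the two open-chain compounds together (no change at the digits printed from compound 2 to compound 4 (within the scatter)). The ring-to-chain change now holds at an equal count of 6 heavy atoms (a 160-fold higher number from compound 3 to compound 4 (2.19 log units; beyond the scatter)) and gives a step of the same size from the six-membered ring (a 160-fold higher number from compound 1 to compound 4 (2.21 log units; beyond the scatter)), so across these four compounds ring versus no ring separates the values while heavy-atom count does not, and none of the four goes against this. No measurement shown gives a reason for this split.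

As far as these compounds go, whether a carboxylic acid at the end of the open chain, or an amine in place of the terminal hydroxy of compound 4, would stay with the open-chain compounds or move toward compound 1 and compound 3 remains open. Also open, from the compounds shown here alone, is whether a five-membered ring without its carbonyl would stand with compound 3.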